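A few compounds are considered here, and "the series" means these few. Any claim that something is new, unique, unknown or untested is made for them only; others in the source may bear on it.

Measured so far:
compound 1, `C[C@H](NC(=O)c1ccccc1)C(=O)N(C)/N=N/c1ccc(C#N)cc1`, 9.2 h
compound 2, `CC(=O)NCC(=O)N(C)/N=N/c1ccc(C#N)cc1`, 7.6 h

Both were read in a physicochemical assay for metabolic stability, read by HPLC, in phosphate buffer, at pH 7.7; a higher number here means that the compound lasts longer, a lower number that the compound disappears faster. Compound 1 gives 9.2 h there, and compound 2 gives 7.6 h; the two numbers sit within the usual scatter of each other, so neither compound can be set apart from the other on this read-out. Compound 3, `CC(=O)N[C@@H](C)C(=O)N(C)/N=N/c1ccc(C#N)cc1`, is not yet measured. It differs from compound 1 in one place: methyl in place of phenyl on a carbonyl carbon. Among the measured compounds shown here, no measured pair shows this same change, so there is no step to lean on. What there is, is compound 2, which also carries the acetyl and whose half-life in this assay stands close to that of compound 1. In this assay a step of no size beyond the scatter is expected, if anything slightly downward. For compound 3 the half-life is estimated at 8 h, within 5 h to 13 h. The expected step is a 1.2-fold lower number from compound 1 to compound 3 (0.06 log units; within the scatter).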

Compound 3, half-life: 9.8 h
Compound 3: middle estimate off by 1.2-fold (0.09 log units), on the low side; the range from low to high includes it.
By their numbers in this assay, from the lowest: compounds 2, 1 and 3 (each within the scatter of the next).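

In this assay, among the compounds shown here, the change from benzoyl to acetyl, methyl in place of phenyl on a carbonyl carbon, gives a 1.1-fold higher number from compound 1 to compound 3 (0.03 log units; within the scatter) and for the first time isolates this single change, so the phenyl is not needed to keep the half-life in this range. Methyl in place of hydrogen on a saturated chain carbon bound to an amide-type nitrogen and a carbonyl carbon gives a 1.3-fold higher number from compound 2 to compound 3 (0.11 log units; within the scatter) and shows no readable difference at that place either. Nothing at hand explains either result.

These compounds carry only phenyl or methyl on the carbonyl carbon, and only hydrogen or methyl on the chain carbon. From the compounds shown here alone, whether a longer chain on the carbonyl carbon, or an amine or a carboxylic acid on the chain carbon, would move the half-life beyond the scatter remains open.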